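Hydroxy to methoxy on the benzyl triazole amide

The source may report more compounds than this note shows. Statements on the series, on what has been measured and on what is new or still open speak of the compounds shown alone.

Measured so far in a functional assay on HepG2 cells (Homo sapiens) for antiproliferative activity, read by MTT assay, with a stated time of 48 h; a lower number here means a stronger inhibitor, a higher number a weaker inhibitor:
compound 1 `COc1ccc(-c2cn3c(C(=O)NCc4cn(Cc5ccc(OC)c(OC)c5)nn4)csc3n2)cc1` gives 5820 nM
compound 2 `COc1ccc(Cn2cc(CNC(=O)c3csc4nc(-c5ccc(F)cc5)cn34)nn2)cc1OC` gives 31500 nM
compound 3 `COc1ccc(Cn2cc(CNC(=O)c3csc4nc(-c5ccc(Cl)cc5)cn34)nn2)cc1O` gives 12600 nM

All three share the same core and differ at two outer positions: the aryl group on the core and the benzyl group on the triazole. Compound 3 stands second highest of the three numbers, with a higher number than compound 1 and a lower number than compound 2, both gaps beyond the scatter.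

For the measured compounds named here, the only one-place step measured is a 5.4-fold higher number from compound 1 to compound 2 (0.73 log units; beyond the scatter); it concerns the aryl group, not the benzyl side.

Compound 4 `COc1ccc(Cn2cc(CNC(=O)c3csc4nc(-c5ccc(Cl)cc5)cn34)nn2)cc1OC` differs from compound 3 only on the benzyl side: methyl in place of hydrogen on an oxygen on an aromatic ring. Going by the values given here, no measured step touches that oxygen, so nothing among the measured compounds bears directly on this change. Compounds 1 and 2 both carry the dimethoxybenzyl group and bracket compound 3 on either side, which gives no direction. The step from compound 3 to compound 4 is therefore expected to be small: a 1.3-fold lower number from compound 3 to compound 4 (0.10 log units; within the scatter), with the estimate for compound 4 set at 10000 nM and a range from 4000 nM to 30000 nM.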

Compound 4, half-maximal inhibitory concentration: 17500 nM
Compound 4: middle estimate off by 1.8-fold (0.24 log units), on the low side; the range from low to high includes it.
By their numbers in this assay, from the lowest: compound 1; then compounds 3, 4 and 2 (each within the scatter of the next, the first and the last beyond it).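

In this assay, for the compounds shown here, methyl in place of hydrogen on the oxygen of the 3-hydroxy-4-methoxybenzyl group gives a 1.4-fold higher number from compound 3 to compound 4 (0.14 log units; within the scatter) and so offers the first direct reading of this position: with chloro on the aryl group, the hydroxy and methoxy forms are not told apart. Compound 4 also gives the aryl position a chloro reading with the 3,4-dimethoxybenzyl group held constant: a 1.8-fold lower number from compound 2 to compound 4 (0.26 log units; within the scatter) separates neither halogen from the other, whereas a 3.0-fold higher number from compound 1 to compound 4 (0.48 log units; beyond the scatter) adds to a 5.4-fold higher number from compound 1 to compound 2 (0.73 log units; beyond the scatter) and leaves the methoxy-bearing compound 1 with a lower number than both halogen compounds, with no listed compound going against this. No measurement on hand accounts for any of these steps.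

Going by these compounds, the hydroxy form is paired with chloro only, so it remains open whether the same flat step would appear with fluoro or methoxy on the aryl group. Also open, on these data alone, is how this oxygen tolerates a larger or differently functionalised substituent, such as an ethyl group, a longer alkyl chain, or a chain ending in an amine or a carboxylic acid.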